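From a Piperazine Chain to a Benzimidazole

The compounds below may be only part of what the source reports. "The series", "measured", "known", "first", "only" and "open" are said of these compounds alone.

Within the data shown here, in a functional assay on A549 cells (Homo sapiens) for cytotoxicity, read by MTT assay, with a stated time of 48 h (a higher number here means a weaker inhibitor, a lower number a stronger inhibitor), compound 2 `COc1c(OCCCCN2CCNCC2)cc(O)c2c(=O)cc(-c3ccccc3)oc12` gives 1740 nM, the only actual number among the compounds measured so far. Compound 1 `COc1c(OCc2cnoc2C)cc(O)c2c(=O)cc(-c3ccccc3)oc12` reaches only a limit of the assay, > 100000 nM. Compound 3 `COc1c(O)cc(O)c2c(=O)cc(-c3ccc(Cl)cc3)oc12` offers no comparison, as its entry reads "not determined" (no result reported).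

The next compound to be tested in this assay is compound 4 `COc1c(OCc2nc3ccccc3[nH]2)cc(O)c2c(=O)cc(-c3ccccc3)oc12`. It keeps the core of compound 2 but changes the side group: 1H-benzimidazol-2-yl in place of 3-(piperazin-1-yl)propyl on a saturated chain carbon bound to an oxygen on an aromatic ring. Put another way, 4-(piperazin-1-yl)butyl gives way to (1H-benzimidazol-2-yl)methyl, so the six-membered non-aromatic ring is lost and two aromatic rings arrive.

Among the measured compounds shown here, only one measured step bears on this change. It is an at least 57-fold lower number from compound 1 to compound 2 (1.75 log units; beyond the scatter), and it came with 3-(piperazin-1-yl)propyl in place of 5-methyl-1,2-oxazol-4-yl at the same place. Compound 4 also loses the piperazine chain and has an aromatic group at that carbon, as compound 1 does, so much of that large step may be undone. The two aromatic groups differ, however, and a single step is thin support, so a full return to the limit is not assumed. The step expected here is a 14-fold higher number from compound 2 to compound 4 (1.16 log units; beyond the scatter), a clear move towards a weaker inhibitor. Compound 4 is estimated at 25000 nM, with an expected range from 5000 nM to 100000 nM.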

Compound 4, half-maximal inhibitory concentration: > 100000 nM
Compound 4 ended at the assay's limit; the forecaster's own chance of this, stated with the estimate: 35%; at least 4.0-fold (0.60 log units) between middle value and limit.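

Among these compounds, until now only one group, 5-methyl-1,2-oxazol-4-yl, had been seen to fall far short of the piperazine chain on this saturated chain carbon bound to an oxygen on an aromatic ring; in this assay, a second and quite different group does the same, as 1H-benzimidazol-2-yl in place of 3-(piperazin-1-yl)propyl brings an at least 57-fold higher number from compound 2 to compound 4 (1.75 log units; beyond the scatter). The heavy atoms that enter match in number and kind those that leave, so that count does not separate the two compounds, while the groups differ in their rings and in the chain that carries them. The true size of this step stays hidden, and the step from compound 1 to compound 4 cannot be read, because both of those compounds give only a limit: the limit of > 100000 nM in this assay, at which 2 of the 4 values shown sit.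

The compounds shown leave open which part of the side group of compound 2 matters: the piperazine ring, its free amine or the length of the chain. A shorter chain ending in the same piperazine, or the same chain ending in a morpholine or a dimethylamine, would begin to separate these parts.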